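The compounds below may be only part of what the source reports. "The series", "measured", "known", "first", "only" and "open" are said of these compounds alone.

Measured in a functional assay on L1210 cells (Mus musculus) for antiproliferative activity, read by cell counting, with a stated time of 96 h; on this read-out higher numbers stand for weaker inhibition and lower numbers for stronger inhibition:
- compound 1 `CC(=O)c1ccc(Oc2ccccc2NC(C)=C2C(=O)CC(c3ccccc3)CC2=O)cc1`: 190 nM
- compound 2 `COc1ccc(Oc2ccccc2NC(C)=C2C(=O)CC(c3ccccc3)CC2=O)cc1`: 140 nM
- compound 3 `CC(Nc1ccccc1Oc1ccccc1)=C1C(=O)CC(c2ccccc2)CC1=O`: 86 nM

Two measured steps place compound 3: a 1.6-fold lower number from compound 2 to compound 3 (0.21 log units; within the scatter), and a 2.2-fold lower number from compound 1 to compound 3 (0.34 log units; beyond the scatter). It therefore stands level with compound 2 and apart from compound 1.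

Compound 4 `COc1cc(Oc2ccccc2NC(C)=C2C(=O)CC(c3ccccc3)CC2=O)ccc1N` differs from compound 3 by one change: 4-amino-3-methoxyphenyl in place of phenyl on an oxygen on an aromatic ring. Both steps remove a ring group in favour of hydrogen, so the reverse change, adding groups to that ring, is expected to give a small rise in this assay, perhaps not beyond the scatter. For the measured compounds named here, no measured compound carries the amino group, so that part of the change remains open.

The expected size of the change is a 1.7-fold higher number from compound 3 to compound 4 (0.24 log units; within the scatter).

For compound 4 the estimated value is 150 nM, with an expected range of 60 nM to 380 nM.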

Compound 4, half-maximal inhibitory concentration: 26 nM
The estimate for compound 4 lay 5.8-fold (0.76 log units) above the measured number; the whole stated range lies above it.
By their numbers in this assay, from the lowest: compound 4; then compounds 3, 2 and 1 (each within the scatter of the next, the first and the last beyond it).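

In this assay, for the compounds shown here, 4-amino-3-methoxyphenyl in place of phenyl on an oxygen on an aromatic ring gives a 3.3-fold lower number from compound 3 to compound 4 (0.52 log units; beyond the scatter), so a substituted ring at this position can reach a lower number than phenyl, which the earlier compounds did not show. The same ring also gives a 5.4-fold lower number from compound 2 to compound 4 (0.73 log units; beyond the scatter) and a 7.3-fold lower number from compound 1 to compound 4 (0.86 log units; beyond the scatter) when it replaces 4-methoxyphenyl and 4-acetylphenyl. Nothing available accounts for this drop.

The compounds shown leave open whether the amino group, the methoxy group or the two together carry the drop. 4-Aminophenyl and 3-methoxyphenyl on that oxygen would separate these parts of the change.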